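This account rests on a few compounds, and the source may have more. Where it says the series, first, only, none or still open, it means among the compounds named here.

In a functional assay on V79 cells (Cricetulus griseus) for cytotoxicity, read by colony formation (on this read-out lower numbers stand for stronger inhibition and higher numbers for weaker inhibition), three compounds with a shared core differ in one group on an aromatic carbon. Compound 1 `O=C(O)c1cn(C2CC2)c2c(Cl)c(N3CCCC3)c(F)cc2c1=O` gives 150 ug/mL, compound 2 `O=C(O)c1cn(C2CC2)c2c(Cl)c(N3CCNCC3)c(F)cc2c1=O` gives 43 ug/mL and compound 3 `NC1CCN(c2c(F)cc3c(=O)c(C(=O)O)cn(C4CC4)c3c2Cl)CC1` gives 18 ug/mL, the lowest of the three numbers. Compound 4 `NC1CCCN(c2c(F)cc3c(=O)c(C(=O)O)cn(C4CC4)c3c2Cl)C1` has the same atoms as compound 3, joined differently, with 3-aminopiperidin-1-yl in place of 4-aminopiperidin-1-yl on an aromatic carbon. The measured swaps of this group were all modest: a 3.5-fold lower number from compound 1 to compound 2 (0.54 log units; beyond the scatter), a 2.4-fold lower number from compound 2 to compound 3 (0.38 log units; beyond the scatter) and an 8.3-fold lower number from compound 1 to compound 3 (0.92 log units; beyond the scatter). None of them tests this exact change, so they offer only a loose guide, and no step beyond the scatter is expected. The estimated step is a 1.2-fold higher number from compound 3 to compound 4 (0.09 log units; within the scatter). For compound 4 the expected value is 22 ug/mL, within an estimated range of 9 ug/mL to 55 ug/mL.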

Compound 4, half-maximal inhibitory concentration: 24 ug/mL
The estimate for compound 4 lay 1.1-fold (0.04 log units) below the measured number; the measured number falls inside the stated range.
By their numbers in this assay, from the lowest: compounds 3, 4 and 2 (each within the scatter of the next, the first and the last beyond it); then compound 1.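

In this assay, 3-aminopiperidin-1-yl in place of 4-aminopiperidin-1-yl gives a 1.3-fold higher number from compound 3 to compound 4 (0.12 log units; within the scatter), so the two arrangements of the same atoms cannot be told apart on this aromatic carbon. Against piperazin-1-yl the result is a 1.8-fold lower number from compound 2 to compound 4 (0.25 log units; within the scatter), while against pyrrolidin-1-yl it is a 6.3-fold lower number from compound 1 to compound 4 (0.80 log units; beyond the scatter), which leaves compound 1 apart from compound 4. Nothing available explains these numbers. The compounds shown leave open whether the amine itself matters, which a 4-hydroxypiperidin-1-yl group, with a hydroxyl in its place, would address.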